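Halogen pattern on the anilino phenyl and MV4-11 inhibition

This account rests on a few compounds, and the source may have more. Where it says the series, first, only, none or still open, it means among the compounds named here.

Measured so far:
compound 1 `Cc1n[nH]c2ccc(-c3nc4cnc(N5CCN(C)CC5)cn4c3Nc3ccc(F)cc3)cc12` 0%
compound 2 `Cc1n[nH]c2ccc(-c3nc4cnc(N5CCN(C)CC5)cn4c3Nc3ccc(Br)cc3)cc12` 83%
compound 3 `Cc1n[nH]c2ccc(-c3nc4cnc(N5CCN(C)CC5)cn4c3Nc3ccc(F)c(Cl)c3)cc12` 84.1%

In a functional assay on MV4-11 cells (Homo sapiens) for inhibition, with a stated time of 120 h, tested at 10 uM (on this read-out higher numbers stand for more inhibition at the one concentration tested (going by the name of the read-out) and lower numbers for less inhibition), compound 3 gives 84.1%, the highest of the three numbers; compound 2 sits a number 1.1 percentage points higher from compound 2 to compound 3 (within the scatter) away, so the two cannot be ordered, while compound 1 lies far off at 0%. Compound 4 `Cc1n[nH]c2ccc(-c3nc4cnc(N5CCN(C)CC5)cn4c3Nc3cc(Cl)ccc3Cl)cc12` is the next step from compound 3: 2,5-dichlorophenyl in place of 3-chloro-4-fluorophenyl on a nitrogen on an aromatic ring.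

Among the measured compounds shown here, two measured steps bear on it. The step of a number 83 percentage points higher from compound 1 to compound 2 (beyond the scatter) and the step of a number 84.1 percentage points higher from compound 1 to compound 3 (beyond the scatter) both show that moving from a single fluoro to a heavier or an added halogen on this phenyl turns a silent compound into a strongly inhibiting one. The step of a number 1.1 percentage points higher from compound 2 to compound 3 (within the scatter) shows that, once such a halogen is present, redistributing the halogens between 4-bromophenyl and 3-chloro-4-fluorophenyl changes nothing beyond the scatter. For the measured compounds named here, compound 4 keeps two chlorines on the ring, but the 2,5-dichlorophenyl arrangement has no measured precedent here, so the expectation is broad. For compound 4 a step of about a number 9.1 percentage points lower from compound 3 to compound 4 (within the scatter) is expected, within the scatter. Compound 4 is therefore estimated at 75%, in the range 35% to 95%.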

Compound 4, a percentage reported as inhibition, at one concentration (the size of the read-out at that concentration, not a potency): 23.8%
Beside the measured number, compound 4's estimate is 51.2 percentage points above it; the whole stated range lies above it.
By their numbers in this assay, from the lowest: compound 1; then compound 4; then compounds 2 and 3 (each within the scatter of the next).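

In this assay, carrying two chlorines does not secure strong inhibition: the change from 3-chloro-4-fluorophenyl to 2,5-dichlorophenyl is a number 60.3 percentage points lower from compound 3 to compound 4 (beyond the scatter) and the change from 4-bromophenyl to 2,5-dichlorophenyl is a number 59.2 percentage points lower from compound 2 to compound 4 (beyond the scatter) so the arrangement of the halogens on this phenyl matters, not only their presence. The 2,5-dichlorophenyl group still stands clear of 4-fluorophenyl, with a number 23.8 percentage points higher from compound 1 to compound 4 (beyond the scatter) so the series now holds an intermediate level rather than only silent and strongly inhibiting compounds. Nothing available explains why this arrangement gives less inhibition.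

The compounds shown do not separate what each chlorine of 2,5-dichlorophenyl does on its own. Going by these compounds, how a methoxy or a trifluoromethyl group on this phenyl would compare with the halogens also remains open.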